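Fluorine on the aryl ring of a diphenylmethylene succinimide

The source may hold more compounds than are shown below. What is called first, only, known or untested is meant among the compounds shown, and "the series" means these compounds.

Measured compounds:
compound 1, `O=C1CC(=C(c2ccccc2)c2ccccc2)C(=O)N1CN1CCN(c2cccc(Cl)c2)CC1`, 392 nM
compound 2, `O=C1CC(=C(c2ccccc2)c2ccccc2)C(=O)N1CCCN1CCN(c2ccccc2)CC1`, 5.7 nM

Of the compounds shown here, two have been measured in an assay on membranes from Cerebral cortex for binding affinity to Adrenergic receptor alpha-1 (Rattus norvegicus), read by radioligand binding; a lower number here means a stronger inhibitor, a higher number a weaker inhibitor. Compound 1 gives 392 nM, and compound 2 gives 5.7 nM. Compound 2 therefore stands as the lowest of the two numbers, and the gap to compound 1 lies well beyond the scatter; the two differ in more than one place, so the gap cannot be traced to a single change.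

Compound 3, `O=C1CC(=C(c2ccccc2)c2ccccc2)C(=O)N1CCCN1CCN(c2ccc(F)cc2)CC1`, has not yet been measured in this assay. It differs from compound 2 in one place: fluoro in place of hydrogen on an aromatic carbon. Going by the values given here, no measured pair in this set isolates such a change, so there is no direct precedent to lean on.

The author expects compound 3 to stay close to compound 2, with a step of a 1.2-fold higher number from compound 2 to compound 3 (0.09 log units; within the scatter) that is not beyond the scatter in either direction. The estimate for compound 3 in this assay is 7 nM, with a range from 2.5 nM to 20 nM.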

Compound 3, inhibition constant: 8.3 nM
Beside the measured number, compound 3's estimate is 1.2-fold (0.07 log units) below it; the range from low to high includes it.
By their numbers in this assay, from the lowest: compounds 2 and 3 (each within the scatter of the next); then compound 1.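

In this assay, going by these compounds alone, replacing phenyl with 4-fluorophenyl gives a 1.5-fold higher number from compound 2 to compound 3 (0.16 log units; within the scatter), the first step in this set that isolates a change in one place. Compounds 2 and 3 cannot be told apart here, so this aromatic carbon, para to a large group, accepts fluoro in place of hydrogen with no effect that can be read beyond the scatter; the earlier pair of compounds could not show this, as they differ in more than one place. No accompanying measurement bears on why the fluoro atom leaves the number within the scatter.

Going by these compounds, a single atom at a single carbon says little about the position as a whole, so it remains open whether a larger group there, such as methoxy or trifluoromethyl, would also stay within the scatter of compound 2. On these data alone, it also remains open whether fluoro would behave the same way on another carbon of this aromatic ring, or on a compound with a longer chain joining this ring to the shared core.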